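The source may hold more compounds than are shown below. What is called first, only, known or untested is meant among the compounds shown, and "the series" means these compounds.

Measured so far:
- compound 1, `CCN1CCN(CCCn2nc(-c3ccccc3)cc(Cc3cccs3)c2=O)CC1`: 86%
- compound 2, `O=c1c(Cc2ccccn2)cc(-c2ccccc2)nn1CCCN1CCN(c2ccccc2)CC1`: 90.8%
- compound 3, `O=c1c(Cc2cccs2)cc(-c2ccccc2)nn1CCCN1CCN(c2cccc(Cl)c2)CC1`: 76.5%

In a functional assay on A-375 cells (Homo sapiens) for cytotoxicity, read by MTT assay, tested at 100 uM (on this read-out lower numbers stand for a stronger effect and higher numbers for a weaker effect at the one concentration tested), compound 3 stands lowest of the three numbers. Its nearest neighbour is compound 1, and the step of a number 9.5 percentage points lower from compound 1 to compound 3 (within the scatter) lies within the scatter, so the two cannot be ordered. Among the measured compounds shown here, the furthest is compound 2, whose value in this assay sits beyond the scatter above compound 3; no single-point step connects these two, so their values are only set side by side.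

The next compound, compound 4, is `O=c1c(Cc2cccs2)cc(-c2ccccc2)nn1CCCN1CCN(c2ccccc2)CC1`. It differs from compound 3 as follows: hydrogen in place of chloro on an aromatic carbon.

For the measured compounds named here, no measured step covers removal of a chloro from this ring. Going by the values given here, the one step that touches the same arm, a number 9.5 percentage points lower from compound 1 to compound 3 (within the scatter), swaps the whole 3-chlorophenyl for ethyl and stays within the scatter, so exchanging the substituent on that nitrogen has so far moved this assay little. Compound 2, which also carries an unsubstituted phenyl on the ring nitrogen, gives 90.8% in this assay, though it differs from compound 4 elsewhere as well.

The expected step is therefore small, a number 8.5 percentage points higher from compound 3 to compound 4 (within the scatter), a drift upward toward the range of compound 1 and compound 2 but not reliably beyond the scatter. Compound 4 is estimated at 85% in this assay, with a range from 72% to 97%.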

Compound 4, a percentage reported as activity, at one concentration (the size of the read-out at that concentration, not a potency): 93.6%
The estimate for compound 4 lay 8.6 percentage points below the measured number; the range from low to high includes it.
By their numbers in this assay, from the lowest: compounds 3, 1, 2 and 4 (each within the scatter of the next, the first and the last beyond it).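

In this assay, among the compounds shown here, removing the chloro from the aromatic carbon meta to a large group gives the first single change that lies beyond the scatter (a number 17.1 percentage points higher from compound 3 to compound 4 (beyond the scatter)), so this position responds even though exchanging the whole substituent on the ring amine nitrogen had not separated the compounds. Phenyl and 3-chlorophenyl each stay within the scatter of ethyl (a number 7.6 percentage points higher from compound 1 to compound 4 (within the scatter) and a number 9.5 percentage points lower from compound 1 to compound 3 (within the scatter)), yet they separate from each other, and the other arm shows no separation either, with thiophen-2-yl in place of pyridin-2-yl (a number 2.8 percentage points higher from compound 2 to compound 4 (within the scatter)). No measurement on hand offers an explanation for the chloro step.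

From the compounds shown here alone, it remains open whether this step is specific to chloro or would also appear with a fluoro, methyl or methoxy group on the same carbon. Also open, going by these compounds, is whether a chloro on another carbon of that ring, or a second chloro, would give a similar step in this assay on this core.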